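The source may hold more compounds than are shown below. What is called first, only, known or untested is meant among the compounds shown, and "the series" means these compounds.

In a functional assay on A549 cells (Homo sapiens) for cytotoxicity, with a stated time of 48 h (a higher number here means a weaker inhibitor, a lower number a stronger inhibitor), three compounds sharing one core have been measured so far. Compound 1 (`CC(C)COc1ccc2oc(/C=C/[S+](C)[O-])cc(=O)c2c1`) gives 1100 nM and compound 2 (`CC(C)CC(=O)Oc1ccc2oc(/C=C/[S+](C)[O-])cc(=O)c2c1`) gives 2300 nM as its value, while compound 3 (`CCCCOc1ccc2oc(/C=C/[S+](C)[O-])cc(=O)c2c1`) gives 1400 nM as its value. Compound 3 cannot be told apart from either of the others, as both of its steps (a 1.3-fold higher number from compound 1 to compound 3 (0.10 log units; within the scatter)) and (a 1.6-fold lower number from compound 2 to compound 3 (0.22 log units; within the scatter)) stay within the scatter.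

Compound 4 (`CCCCC(=O)Oc1ccc2oc(/C=C/[S+](C)[O-])cc(=O)c2c1`) is still unmeasured. It carries butylcarbonyl in place of butyl on an oxygen on an aromatic ring. Within the data shown here, the closest parallel is isobutylcarbonyl in place of isobutyl at that same oxygen, a modest change (a 2.1-fold higher number from compound 1 to compound 2 (0.32 log units; beyond the scatter)) and the only step here beyond the scatter. A less direct comparison, butyl in place of isobutylcarbonyl, also changes the chain shape, and read backwards it points the same way, though its size stays within the scatter (a 1.6-fold lower number from compound 2 to compound 3 (0.22 log units; within the scatter)). This is thin evidence, resting on one clean pair, so the step expected in this assay is modest and towards a higher number (a 1.9-fold higher number from compound 3 to compound 4 (0.29 log units; within the scatter)). Compound 4 is therefore estimated at 2700 nM (expected range 1400 nM to 5000 nM).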

Compound 4, half-maximal inhibitory concentration: 2400 nM
For compound 4 the middle estimate is 1.1-fold (0.05 log units) above the measured one, and the stated range covers the measured number.
By their numbers in this assay, from the lowest: compounds 1, 3, 2 and 4 (each within the scatter of the next, the first and the last beyond it).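

Adding the carbonyl to the straight chain gives a 1.7-fold higher number from compound 3 to compound 4 (0.23 log units; within the scatter), so this pair alone cannot be told apart, and the effect seen with the branched chain is not confirmed as a separate step here. Among these compounds, the only new step beyond the scatter is a 2.2-fold higher number from compound 1 to compound 4 (0.34 log units; beyond the scatter), which swaps isobutyl for butylcarbonyl and so changes both the carbonyl and the chain shape at once. With the carbonyl present, the chain shape makes no readable difference, as a 1.0-fold higher number from compound 2 to compound 4 (0.02 log units; within the scatter) shows, and this change behaves alike with and without the carbonyl: the same change on two cores in this assay, a 1.3-fold higher number (0.10 log units; within the scatter) from compound 1 to compound 3 and a 1.0-fold higher number (0.02 log units; within the scatter) from compound 2 to compound 4, 1.2-fold (0.09 log units) apart, within the scatter of two such steps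

From the compounds shown here alone, the four compounds cover only four-carbon chains and their carbonyl counterparts on this oxygen, so it remains open how a longer chain such as octyl, a ring-bearing group such as benzyl, or a chain ending in an amine would behave there. With compound 3 within the scatter of both compound 2 and compound 4, these data also cannot settle whether the carbonyl matters in general or only in the comparisons with compound 1.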